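Exposure After Swapping One Pyrazole for an Ester

The compounds below may be only part of what the source reports. "The series", "measured", "known", "first", "only" and "open" are said of these compounds alone.

Values in an in vivo ADME assay on the whole organism (plasma) for pharmacokinetics, with Rattus norvegicus as the target, at a dose of 10 mg/kg by the oral route; on this read-out higher numbers stand for higher exposure at the dose given and lower numbers for lower exposure:
- Compound 1 `O=C1N(Cc2cccc(-c3cc[nH]n3)c2)[C@H](Cc2ccccc2)[C@H](O)[C@@H](O)[C@@H](Cc2ccccc2)N1Cc1cccc(-c2cc[nH]n2)c1`: 68 nM
- Compound 2 `O=C1N(Cc2cccc(-c3cn[nH]c3)c2)[C@H](Cc2ccccc2)[C@H](O)[C@@H](O)[C@@H](Cc2ccccc2)N1Cc1cccc(-c2cn[nH]c2)c1`: 75 nM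
- Compound 3 `O=C1N(Cc2cccc(-c3c[nH]cn3)c2)[C@H](Cc2ccccc2)[C@H](O)[C@@H](O)[C@@H](Cc2ccccc2)N1Cc1cccc(-c2c[nH]cn2)c1`: < 42 nM (a limit of the assay, not a number)

Compound 1 and compound 2 lie within the usual scatter of each other, so this assay does not separate them. Compound 1 therefore shares the top of this small set with compound 2. The third value marks (the limit of < 42 nM in this assay, at which 1 of the 3 values shown sits).

Compound 4 `COC(=O)c1cccc(CN2C(=O)N(Cc3cccc(-c4cc[nH]n4)c3)[C@H](Cc3ccccc3)[C@H](O)[C@@H](O)[C@H]2Cc2ccccc2)c1` has not yet been measured. It keeps the shared core of compound 1, but on one of the two benzyl arms methoxycarbonyl replaces 1H-pyrazol-3-yl on an aromatic carbon: methoxycarbonyl in place of 1H-pyrazol-3-yl on an aromatic carbon.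

Among the measured compounds shown here, no measured pair shows a single change of this kind, so the expectation rests on little. For the measured compounds named here, only one arm changes, and the starting point is compound 1 at 68 nM, so no step beyond the scatter is expected. The expected step is a 1.1-fold lower number from compound 1 to compound 4 (0.05 log units; within the scatter), and it could go either way. For compound 4 the estimate is 60 nM, with an expected range of 20 nM to 200 nM.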

Compound 4, maximal plasma concentration: 320 nM
For compound 4 the middle estimate is 5.3-fold (0.73 log units) below the measured one, outside the stated range (above it).
By their numbers in this assay, from the lowest: compounds 1 and 2 (each within the scatter of the next); then compound 4. At a limit, below all of these: compound 3.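

Compounds 1, 2 and 3 all carry a five-membered aromatic ring on both benzyl arms, so they could not show what happens when one arm loses that ring. In this assay, putting methoxycarbonyl in place of 1H-pyrazol-3-yl on a single arm gives a 4.7-fold higher number from compound 1 to compound 4 (0.67 log units; beyond the scatter), which shows that this position can shift oral exposure and that one arm alone is enough to do so. Nothing measured here accounts for the rise.

This single pair cannot separate the effect of losing 1H-pyrazol-3-yl from that of gaining methoxycarbonyl. As far as these compounds go, it also remains open whether a carboxylic acid, an amide or a nitrile on the same aromatic carbon would behave alike, and whether methoxycarbonyl on the second arm would raise the number further.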